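The source may hold more compounds than are shown below. What is called first, only, known or untested is meant among the compounds shown, and "the series" means these compounds.

Among the compounds with values here, in a functional assay on A-375 cells (Homo sapiens) for cytotoxicity, read by CCK-8 assay, with a stated time of 24 h (on this read-out lower numbers stand for stronger inhibition and higher numbers for weaker inhibition), compound 2 `COc1ccccc1Oc1c(N)nc(-c2ccc(Br)cc2)nc1Cl` gives 63 nM, the only exact number so far. Compound 1 `COc1ccc(-c2nc(N)c(Oc3ccccc3OC)c(Cl)n2)cc1` reads > 80000 nM, which is a limit of the assay and not a number. Within the data shown here, the single measured step, an at least 1200-fold lower number from compound 1 to compound 2 (3.10 log units; beyond the scatter), is large and comes from bromo in place of methoxy on an aromatic carbon. It shows that the substituent on this aryl group can carry much of the activity in the pair. Compound 3 `COc1ccccc1Oc1c(N)nc(-c2cccc(I)c2)nc1Cl` alters that same group: 3-iodophenyl in place of 4-bromophenyl on an aromatic carbon. Among the measured compounds shown here, a halogen remains, but both its identity and its position change, and no measured step covers either change. A moderate rise in the number in this assay is therefore expected, beyond the scatter but well short of the measured step. The expected step is a 9.5-fold higher number from compound 2 to compound 3 (0.98 log units; beyond the scatter). For compound 3 the estimate is 600 nM, with an expected range of 70 nM to 10000 nM.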

Compound 3, half-maximal inhibitory concentration: 2200 nM
Estimate against measurement, compound 3: 3.7-fold (0.56 log units) below; measured number inside the range.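

In this assay, keeping a halogen on this aryl group does not keep the level of compound 2: the change to 3-iodophenyl gives a 35-fold higher number from compound 2 to compound 3 (1.54 log units; beyond the scatter). The 3-iodophenyl group still reads well clear of the 4-methoxyphenyl group, with an at least 36-fold lower number from compound 1 to compound 3 (1.56 log units; beyond the scatter). Compound 1 reads > 80000 nM, which is a limit of the assay and not a number, so this second step is only a bound: the limit of > 80000 nM in this assay, at which 1 of the 3 values shown sits.

The step to compound 3 changes the halogen and its position together, and the compounds shown do not tell how much of the loss belongs to each. Also open, as far as these compounds go, is how this aryl group would read in this assay with an amine or a carboxylic acid in place of the halogen.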